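The source may hold more compounds than are shown below. What is called first, only, known or untested is meant among the compounds shown, and "the series" means these compounds.

Series notes. Compound 1 `Cc1ccc(-n2cc(C(=O)Nc3cc(F)cc(F)c3)c(=O)c3ccc(N(C)C)nc32)cc1OCCCCCCC[N+]1(C)CCCC1` and compound 2 `Cc1ccc(-n2cc(C(=O)Nc3cc(F)cc(F)c3)c(=O)c3ccc(N(C)C)nc32)cc1OCCCCCCC[N+]1(C)CCN(C)CC1` differ only in the charged group on the saturated chain carbon seven bonds along the chain from an oxygen on an aromatic ring. In an assay on LX2 cells for inhibition of COL1A1 promoter (Homo sapiens), read by a luciferase reporter, with a stated time of 24 h, tested at 50 uM (on this read-out higher numbers stand for a stronger effect at the one concentration tested and lower numbers for a weaker effect), compound 1 gives 55.9% while compound 2 gives 25%, the lowest of the two numbers, the step being a number 30.9 percentage points lower from compound 1 to compound 2 (beyond the scatter). Compound 3 `Cc1ccc(-n2cc(C(=O)Nc3cc(F)cc(F)c3)c(=O)c3ccc(N(C)C)nc32)cc1OCCCCCCC[N+](C)(C)C1CCCCC1` carries a group of 9 heavy atoms (8 carbon, 1 nitrogen; one six-membered non-aromatic ring of carbon only) in place of a group of 8 heavy atoms (6 carbon, 2 nitrogen; one six-membered non-aromatic ring with 2 hetero atoms), on a saturated chain carbon, seven bonds along the chain from an oxygen on an aromatic ring. Going by the values given here, only that one step bears on it and it was large; a rise in this assay is expected, roughly a number 25 percentage points higher from compound 2 to compound 3 (beyond the scatter), because compound 1, whose ring holds 1 hetero atom, gives 55.9%. Compound 3 is estimated at 50%, range 30% to 70%.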

Compound 3, a percentage reported as inhibition, at one concentration (the size of the read-out at that concentration, not a potency): 61.7%
Compound 3: the middle estimate sits 11.7 percentage points below what was measured; low and high end bracket the measured number.
By their numbers in this assay, from the lowest: compound 2; then compounds 1 and 3 (each within the scatter of the next).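

In this assay, the ring of carbon only gives a number 36.7 percentage points higher from compound 2 to compound 3 (beyond the scatter), and against the five-membered ring it gives a number 5.8 percentage points higher from compound 1 to compound 3 (within the scatter). A six-membered ring at this position therefore does not by itself go with the low number: of the three compounds, only compound 2, whose ring holds 2 hetero atoms, stands apart. Nothing available gives a cause for this. Still open, on these data alone, is whether the second ring nitrogen or the methyl group on it accounts for the gap. A morpholine ring or a piperidine ring on the same chain would bear on that, and a shorter chain would test how far these readings depend on chain length.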